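The compounds below may be only part of what the source reports. "The series", "measured", "known", "first", "only" and "open" are said of these compounds alone.

Compound 1 `COc1ccc(-c2cc3ccccc3nc2/C=C/C(=O)c2ccc(F)cc2)cc1` gives 830 nM in a functional assay on MDA-MB-231 cells (Homo sapiens) for antiproliferative activity, read by XTT assay, with a stated time of 72 h; a lower number here means a stronger inhibitor, a higher number a weaker inhibitor. Among the three measured compounds it holds the second highest number: compound 3 `COc1ccc(-c2cc3ccccc3nc2/C=C/C(=O)c2ccccn2)cc1` sits nearest with 740 nM, a step of a 1.1-fold lower number from compound 1 to compound 3 (0.05 log units; within the scatter), while compound 2 `COc1ccc(C(=O)/C=C/c2nc3ccccc3cc2-c2ccc(OC)cc2)cc1` lies furthest with 7540 nM, a step of a 9.1-fold higher number from compound 1 to compound 2 (0.96 log units; beyond the scatter). Compound 4 `COc1ccc(-c2cc3ccccc3nc2/C=C/C(=O)c2ccsc2)cc1` differs from compound 1 only at the carbonyl carbon: thiophen-3-yl in place of 4-fluorophenyl on a carbonyl carbon. Among the measured compounds shown here, the steps that bear on this place are a 1.1-fold lower number from compound 1 to compound 3 (0.05 log units; within the scatter) and a 10-fold lower number from compound 2 to compound 3 (1.01 log units; beyond the scatter); exchanging the group on the carbonyl carbon left compound 1 and compound 3 within the scatter, and the large step involves compound 2, whose methoxy group compound 4 does not carry. No step beyond the scatter is therefore expected in this assay. Compound 4 is estimated at 800 nM, between 350 nM and 2000 nM, an expected step of a 1.0-fold lower number from compound 1 to compound 4 (0.02 log units; within the scatter).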

Compound 4, half-maximal inhibitory concentration: 1060 nM
For compound 4 the middle estimate is 1.3-fold (0.12 log units) below the measured one; the measured number falls inside the stated range.
By their numbers in this assay, from the lowest: compounds 3, 1 and 4 (each within the scatter of the next); then compound 2.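

In this assay, the thiophen-3-yl group, a five-membered aromatic ring with one hetero atom, stands level with both 4-fluorophenyl and pyridin-2-yl on the carbonyl carbon, at a 1.3-fold higher number from compound 1 to compound 4 (0.11 log units; within the scatter) and a 1.4-fold higher number from compound 3 to compound 4 (0.16 log units; within the scatter). Compound 2, with its 4-methoxyphenyl group, remains the one set apart, at a 7.1-fold lower number from compound 2 to compound 4 (0.85 log units; beyond the scatter). No measurement shown explains these results. Going by these compounds, whether a saturated ring such as piperidin-4-yl, an amine or a carboxylic acid on the carbonyl carbon would stay level with compound 4 remains open.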